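The source may hold more compounds than are shown below. What is called first, only, known or untested is meant among the compounds shown, and "the series" means these compounds.

Of the compounds shown here, three have already been measured in an assay on cell membranes for binding affinity to adenosine receptor A1 (Cavia porcellus), read by radioligand binding; on this read-out higher numbers stand for weaker inhibition and lower numbers for stronger inhibition. Compound 1 `CCCn1c(=O)c2nc([C@@H]3CC4C=CC3C4)[nH]c2n(CCC)c1=O` gives 4.3 nM. Compound 2 `CC1(Nc2ncnc3c2ncn3C2O[C@H](CO)[C@@H](O)[C@H]2O)CCCCC1` gives 70 nM, and compound 3 `CCCC(CCC)Nc1ncnc2c1ncn2C1O[C@H](CO)[C@@H](O)[C@H]1O` gives 3.3 nM. Within this set compound 1 stands second highest: its nearest neighbour is compound 3, a gap that falls within the usual scatter, while compound 2 sits clearly higher, beyond the scatter.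

Compound 4 `CCCn1c(=O)c2nc(C(C)(C)CCC)[nH]c2n(CCC)c1=O` has not yet been measured. It differs from compound 1 in one place: a group of 6 heavy atoms (6 carbon; no ring) in place of a group of 7 heavy atoms (7 carbon; 2 five-membered non-aromatic rings of carbon only), on an aromatic carbon. The change sits between two ring nitrogen atoms on the core of compound 1.

For the measured compounds named here, only one measured step offers a comparison. Between compound 2 and compound 3 a ring-bearing group was also swapped for an open chain, and there a 21-fold lower number from compound 2 to compound 3 (1.33 log units; beyond the scatter). That step, however, moved from a 1-methylcyclohexyl group to a 1-propylbutyl group and on a different core, so it is only a rough guide. Compound 1 already gives a low number, leaving less room for a large further fall. A small step, or none beyond the scatter, is therefore expected in this assay, slightly towards a higher number. Compound 4 is expected to give 15 nM, within a range from 4 nM to 60 nM. That estimate corresponds to an expected step of a 3.5-fold higher number from compound 1 to compound 4 (0.54 log units; beyond the scatter).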

Compound 4, inhibition constant: 25 nM
Beside the measured number, compound 4's estimate is 1.7-fold (0.22 log units) below it; low and high end bracket the measured number.
By their numbers in this assay, from the lowest: compounds 3 and 1 (each within the scatter of the next); then compound 4; then compound 2.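

In this assay the shift of this position from a group with 2 five-membered non-aromatic rings of carbon only to the open-chain 1,1-dimethylbutyl gives a 5.8-fold higher number from compound 1 to compound 4 (0.76 log units; beyond the scatter) and so shows that the group on this aromatic carbon, between two ring nitrogen atoms, does affect the read-out. The direction differs from that seen in a 21-fold lower number from compound 2 to compound 3 (1.33 log units; beyond the scatter) on a different core, where the open chain sits on a nitrogen on an aromatic ring and the ring-bearing group it replaces is 1-methylcyclohexyl. Across these four compounds, then, replacing a ring-bearing group with an open chain does not move the number one way, and the two steps differ in core, in place and in the groups themselves.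

For the compounds shown here, the single step on this core removes the rings, a double bond outside aromatic rings and a defined stereocentre together, leaving open which of these matters, and whether a cyclopentyl ring or a shorter chain such as tert-butyl at this position would give a number nearer that of compound 1. No measurement shown here bears on the reason for this step.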